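Shifting a Methoxy Group in a Sulfonamide Series

The source may report more compounds than this note shows. Statements on the series, on what has been measured and on what is new or still open speak of the compounds shown alone.

Of the compounds shown here, three built on one shared core have been measured so far, differing only in the aromatic group attached through the amine. Compound 1 `CC(C)(C)c1ccc(CNCCCNS(=O)(=O)c2cc(C(F)(F)F)cc(C(F)(F)F)c2)cc1` gives 2900 nM in a functional assay on A2780 cells (Homo sapiens) for inhibition, read by MTT assay, with a stated time of 72 h; on this read-out lower numbers stand for stronger inhibition of growth and higher numbers for weaker inhibition of growth. Compound 2 `O=S(=O)(NCCCCNCc1ccc(Br)cc1)c1cc(C(F)(F)F)cc(C(F)(F)F)c1` gives 2100 nM in this assay, and compound 3 `COc1ccc(CNCCCNS(=O)(=O)c2cc(C(F)(F)F)cc(C(F)(F)F)c2)cc1` gives 1700 nM. Compound 1 therefore holds the highest of the three numbers, yet every gap is small: the step of a 1.7-fold lower number from compound 1 to compound 3 (0.23 log units; within the scatter), and the step of a 1.2-fold lower number from compound 2 to compound 3 (0.09 log units; within the scatter).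

Compound 4 `COc1ccccc1CNCCCNS(=O)(=O)c1cc(C(F)(F)F)cc(C(F)(F)F)c1` has not yet been measured. It differs from compound 1 by 2-methoxyphenyl in place of 4-(tert-butyl)phenyl on a saturated chain carbon bound to an amine nitrogen. For the measured compounds named here, the measured step that bears most closely on this is the one from compound 1 to compound 3, where methoxy also replaced tert-butyl on an aromatic carbon, although compound 3 carries that methoxy on a different ring carbon than compound 4 does; that step was a 1.7-fold lower number from compound 1 to compound 3 (0.23 log units; within the scatter). Going by the values given here, no measured pair shows what moving the methoxy group from one ring carbon to another does. On this evidence the expected step is a 1.5-fold lower number from compound 1 to compound 4 (0.16 log units; within the scatter), a change not beyond the scatter. Compound 4 is accordingly estimated at 2000 nM, with a range from 900 nM to 4500 nM.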

Compound 4, concentration for 50% growth inhibition: 1500 nM
Beside the measured number, compound 4's estimate is 1.3-fold (0.12 log units) above it; the range from low to high includes it.
By their numbers in this assay, from the lowest: compounds 4, 3, 2 and 1 (each within the scatter of the next).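

For the compounds shown here, compound 4 supplies the first measured pair that isolates where the methoxy group sits on this ring: 2-methoxyphenyl in place of 4-methoxyphenyl, on a saturated chain carbon bound to an amine nitrogen, gives a small step (a 1.1-fold lower number from compound 3 to compound 4 (0.05 log units; within the scatter)), so in this assay these two placements cannot be told apart. The larger exchange of 4-(tert-butyl)benzyl for 2-methoxybenzyl also stays within the scatter (a 1.9-fold lower number from compound 1 to compound 4 (0.29 log units; within the scatter)), as does the step that brings in (2-methoxybenzyl)amino in place of ((4-bromobenzyl)amino)methyl (a 1.4-fold lower number from compound 2 to compound 4 (0.15 log units; within the scatter)), so this position has so far tolerated each of these exchanges without a clear change in growth inhibition. Nothing measured here gives a reason for these small steps.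

The compounds shown all carry a benzyl group with a single ring substituent, so it remains open whether a carboxylic acid, an amine or a nitrile on that ring would produce a step beyond the scatter. From the compounds shown here alone, it is also open how the 2-methoxybenzyl group would behave on a longer chain, with the rest of the shared core unchanged.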